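Series notes: chloroaryl chain on the amide carbonyl

The source may hold more compounds than are shown below. What is called first, only, known or untested is meant among the compounds shown, and "the series" means these compounds.

Three measured compounds share one core, seen in compound 1 `COc1ccc(OCC(=O)N2CCN(c3ccc(C(F)(F)F)cc3[C@@H](N)CC(C)C)CC2)cc1`. In an assay on HEK293 cells for displacement of a labelled ligand from Melanocortin receptor 4 (Homo sapiens) (a higher number here means a weaker inhibitor, a lower number a stronger inhibitor), compound 1 gives 3800 nM, the second highest of the three numbers. Compound 3 `CC(C)C[C@H](N)c1cc(C(F)(F)F)ccc1N1CCN(C(=O)CCNC2CCCCC2)CC1` gives 4800 nM in this assay, and the step of a 1.3-fold higher number from compound 1 to compound 3 (0.10 log units; within the scatter) lies within the scatter. Compound 2 `CC(C)C[C@H](N)c1cc(C(F)(F)F)ccc1N1CCN(C(=O)[C@H](C)Cc2ccc(Cl)cc2)CC1` gives 31 nM; the step of a 120-fold lower number from compound 1 to compound 2 (2.09 log units; beyond the scatter) is the largest in the set, and from the other side it reads a 150-fold higher number from compound 2 to compound 3 (2.19 log units; beyond the scatter).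

Compound 4 `CC(C)C[C@H](N)c1cc(C(F)(F)F)ccc1N1CCN(C(=O)CCC(=O)c2ccc(Cl)cc2)CC1` is unmeasured. It differs from compound 1 by ((4-chlorophenyl)carbonyl)methyl in place of 4-methoxyphenoxy on a saturated chain carbon bound to a carbonyl carbon. The change brings a 4-chlorophenyl group into the side chain, as compound 2 has, but within a ((4-chlorophenyl)carbonyl)methyl group rather than a 1-(4-chlorobenzyl)ethyl group. Among the compounds with values here, the one step that introduces a 4-chlorophenyl group, a 120-fold lower number from compound 1 to compound 2 (2.09 log units; beyond the scatter), is large and downward; the step of a 1.3-fold higher number from compound 1 to compound 3 (0.10 log units; within the scatter), which exchanges the aryl ether for a (cyclohexylamino)methyl group, is flat. A downward step beyond the scatter is therefore expected, but the two groups match only in the chloroaryl part, and the expected step is kept smaller than a 120-fold lower number from compound 1 to compound 2 (2.09 log units; beyond the scatter). For compound 4 the expected value in this assay is 600 nM, with a range from 150 nM to 2500 nM, corresponding to an expected step of a 6.3-fold lower number from compound 1 to compound 4 (0.80 log units; beyond the scatter).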

Compound 4, inhibition constant: 820 nM
For compound 4 the middle estimate is 1.4-fold (0.14 log units) below the measured one; low and high end bracket the measured number.
By their numbers in this assay, from the lowest: compound 2; then compound 4; then compounds 1 and 3 (each within the scatter of the next).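

A 4-chlorophenyl group also lowers the number when it is held in a ((4-chlorophenyl)carbonyl)methyl group on a saturated chain carbon bound to a carbonyl carbon: the change gives a 4.6-fold lower number from compound 1 to compound 4 (0.67 log units; beyond the scatter), and (4-chlorophenyl)carbonyl in place of cyclohexylamino gives a 5.9-fold lower number from compound 3 to compound 4 (0.77 log units; beyond the scatter). The chloroaryl part alone does not reproduce the result for compound 2, as 2-((4-chlorophenyl)carbonyl)ethyl in place of 1-(4-chlorobenzyl)ethyl on a carbonyl carbon gives a 26-fold higher number from compound 2 to compound 4 (1.42 log units; beyond the scatter), so the rest of the chain also counts. No evidence at hand bears on this result.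

Going by these compounds, the chain carbonyl and the methyl branch differ together between these two compounds, and their separate shares remain open. A 3-(4-chlorophenyl)propyl group on the carbonyl carbon, with neither feature, would separate them.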